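A few compounds are considered here, and "the series" means these few. Any claim that something is new, unique, unknown or untested is made for them only; others in the source may bear on it.

- compound 1 `Nc1nn2c(O)cc(-c3ccccc3F)nc2c1[N+](=O)[O-]`: 66.5 ug/mL
- compound 2 `Nc1nn2c(O)cc(CCl)nc2c1[N+](=O)[O-]`: > 50 ug/mL, which is a limit and not a number
- compound 3 `NNCc1cc(O)n2nc(N)c([N+](=O)[O-])c2n1`: 42.6 ug/mL

For the measured compounds named here, in an ADME assay (Homo sapiens) for cytotoxicity (a lower number here means that less compound is tolerated, a higher number that more compound is tolerated), only two of these values are actual numbers, and they cannot be told apart: a 1.6-fold lower number from compound 1 to compound 3 (0.19 log units; within the scatter). Compared with the limit, the only reading is a floor: an at least 1.1-fold lower number from compound 2 to compound 3 (0.06 log units; that floor lies within the scatter).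

Compound 4 `Nc1nn2c(O)cc(CNCCO)nc2c1[N+](=O)[O-]` carries 2-hydroxyethyl in place of amino on an amine nitrogen. Going by the values given here, no measured step changes this nitrogen directly. The nearest evidence is the two steps above, which exchange the larger group containing it, and neither shows a change beyond the scatter. The expected step is therefore small: a 1.2-fold higher number from compound 3 to compound 4 (0.07 log units; within the scatter), with no change beyond the scatter anticipated. For compound 4, the estimated value is 50 ug/mL, with an expected range of 25 ug/mL to 100 ug/mL.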

Compound 4, half-maximal cytotoxic concentration: > 50 ug/mL
Compound 4: only a limit was reported; the forecaster's own chance of this, stated with the estimate: 25%; the middle value sits exactly at the limit.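

In this assay, compound 4 gives > 50 ug/mL, which is a limit and not a number. For the compounds shown here, for the first time a step changes this amine nitrogen directly, putting 2-hydroxyethyl in place of amino, yet it yields only a floor: an at least 1.1-fold higher number from compound 3 to compound 4 (0.06 log units; that floor lies within the scatter). The other two steps to compound 4 cannot be read: the limit of > 50 ug/mL in this assay, at which 2 of the 4 values shown sit.

As far as these compounds go, how far the true value of compound 4 lies past its limit stays open. Also open, from the compounds shown here alone, is whether a carboxylic acid or a longer chain on this amine nitrogen would give a step beyond the scatter.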